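From 4-nitrophenyl to 2-nitrophenyl on the shared core

A few compounds are considered here, and "the series" means these few. Any claim that something is new, unique, unknown or untested is made for them only; others in the source may bear on it.

In an ADME assay on J774.A1 cells (Mus musculus) for cytotoxicity, with a stated time of 48 h (a higher number here means that more compound is tolerated, a lower number that less compound is tolerated), compound 1 (`OC1C(Cn2ccnc2)CCCC1Cn1ccnc1`) gives > 100 ug/mL, which is a limit of the assay and not a number. Going by the values given here, compound 2 (`O=[N+]([O-])c1ccc(OC2C(Cn3ccnc3)CCCC2Cn2ccnc2)cc1`) gives 73.9 ug/mL, the only actual number so far. The next compound is compound 3 (`O=[N+]([O-])c1ccccc1OC1C(Cn2ccnc2)CCCC1Cn1ccnc1`), with 2-nitrophenyl in place of 4-nitrophenyl on an oxygen on a saturated carbon.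

Among the compounds with values here, only one measured step is available: an at least 1.3-fold lower number from compound 1 to compound 2 (0.13 log units; that floor lies within the scatter). That step puts 4-nitrophenyl in place of hydrogen on the same oxygen, and its size is open-ended: the limit of > 100 ug/mL in this assay, at which 1 of the 2 values shown sits. Within the data shown here, no measured step compares 2-nitrophenyl with 4-nitrophenyl, so the series gives no direction for this change. No step beyond the scatter is therefore expected in this assay, and the expectation stays anchored on compound 2 at 73.9 ug/mL. The estimated change is a 1.1-fold lower number from compound 2 to compound 3 (0.02 log units; within the scatter). For compound 3 the expected value is 70 ug/mL, with an estimated range of 35 ug/mL to 100 ug/mL.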

Compound 3, half-maximal cytotoxic concentration: 69.4 ug/mL
For compound 3 the middle estimate is 1.0-fold (0.00 log units) above the measured one, and the stated range covers the measured number.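

In this assay, 2-nitrophenyl in place of 4-nitrophenyl on the oxygen gives a 1.1-fold lower number from compound 2 to compound 3 (0.03 log units; within the scatter), so for this pair the place of the nitro group on the phenyl ring does not separate the two compounds. With 2-nitrophenyl in place of hydrogen on the same oxygen, the reading is an at least 1.4-fold lower number from compound 1 to compound 3 (0.15 log units; that floor lies within the scatter), a floor of the same kind as the one seen with 4-nitrophenyl. Compound 1 stands at a limit and not a number, so the real size of both steps from hydrogen cannot be read: the limit of > 100 ug/mL in this assay, at which 1 of the 3 values shown sits.

The compounds shown do not tell whether the nitro group itself has any part in the numbers of compound 2 and compound 3, a question that a plain phenyl or a 4-aminophenyl on the same oxygen would address. They also do not tell whether an aromatic ring on this oxygen matters at all, which a methyl group, a longer alkyl chain or an acetyl group in the same place would test against the two nitrophenyl compounds.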